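The compounds below may be only part of what the source reports. "The series", "measured", "known", "first", "only" and "open" are said of these compounds alone.

Working notes on the series. The shared core is carried by compound 1 `COc1cc(Cl)cc(-c2nn(-c3cccc(NC(=O)c4ccc(Cl)c(Cl)c4)c3)cc2-c2ccncc2)c1` and by compound 2 `COc1cc(Cl)cc(-c2nn(-c3cccc(NC(=O)Nc4cc(C(F)(F)F)cc(C(F)(F)F)c4)c3)cc2-c2ccncc2)c1`. In a functional assay on PC-3 cells (Homo sapiens) for inhibition, read by sulforhodamine B assay, with a stated time of 48 h, tested at 10 uM (on this read-out lower numbers stand for a stronger effect and higher numbers for a weaker effect at the one concentration tested), compound 1 gives 34%. In the same this assay compound 2 gives -6.27%. Among the compounds with values here, compound 1 thus stands highest of the two numbers so far, and its only neighbour, compound 2, lies lower by a gap beyond the scatter; no single-point step between these two is defined, so only the two values themselves are noted.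

The next compound is compound 3 `COc1cc(Cl)cc(-c2nn(-c3cccc(NC(=O)Nc4ccc(Cl)c(Cl)c4)c3)cc2-c2ccncc2)c1`. Relative to compound 1 it changes in one place: (3,4-dichlorophenyl)amino in place of 3,4-dichlorophenyl on a carbonyl carbon. Read one bond further out, (3,4-dichlorophenyl)carbonyl becomes (3,4-dichlorophenyl)carbamoyl. Compound 2 likewise carries a carbamoyl-type linkage to its aryl group.

Within the data shown here, no measured step covers this change. A downward step is expected in this assay, beyond the scatter, because compound 2 gives -6.27%. The step of a number 22 percentage points lower from compound 1 to compound 3 (beyond the scatter) is the estimated size. Compound 3 is expected to give 12%, with a range from -10% to 34%.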

Compound 3, a percentage reported as activity, at one concentration (the size of the read-out at that concentration, not a potency): -5.03%
Compound 3: the middle estimate sits 17 percentage points above what was measured, and the stated range covers the measured number.
By their numbers in this assay, from the lowest: compounds 2 and 3 (each within the scatter of the next); then compound 1.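

In this assay, within the data shown here, this is the first comparison that isolates one place: on a carbonyl carbon whose other neighbours are an amide-type nitrogen, (3,4-dichlorophenyl)amino in place of 3,4-dichlorophenyl gives a number 39 percentage points lower from compound 1 to compound 3 (beyond the scatter), a stronger effect at the one concentration tested. The 3,4-dichlorophenyl ring itself stays unchanged, so the step goes with the entering amino nitrogen and its one hydrogen-bond donor, which turn the (3,4-dichlorophenyl)carbonyl linkage into (3,4-dichlorophenyl)carbamoyl. The data shown carry no measurement that explains this step.

Still open, going by these compounds, is whether the step depends on the amino nitrogen as such, which a methylene, an ether oxygen or a methylated nitrogen at the same place would test. Also open, on these data alone, is whether the same linkage change gives a step of similar size with aryl groups other than 3,4-dichlorophenyl, such as a 4-methoxyphenyl or a pyridyl group.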